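Benzyl to Fluorophenylethyl on the Amide of Compound 2

The source may hold more compounds than are shown below. What is called first, only, known or untested is meant among the compounds shown, and "the series" means these compounds.

Measured so far:
compound 1 `COC(=O)c1nc(Br)c2cccnc2c1N[C@H]1CC[C@H](N)CC1`: "not determined" (no result reported)
compound 2 `N[C@H]1CC[C@H](Nc2c(C(=O)NCc3ccccc3)nc(Br)c3cccnc23)CC1`: 7000 nM

The shared core carries a bromine, a pyridine-fused ring system and a trans-diaminocyclohexyl group, and the two compounds differ in what hangs off the carboxyl carbon. For compound 1 a functional assay on HCT-116 cells (Homo sapiens) for cytotoxicity, read by MTT assay, with a stated time of 72 h (a higher number here means a weaker inhibitor, a lower number a stronger inhibitor), reports no number, only that it was not determined. Going by the values given here, compound 2 is therefore the only compound with a result in this assay, giving 7000 nM, and nothing else stands beside it for comparison.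

Compound 3 `C[C@H](NC(=O)c1nc(Br)c2cccnc2c1N[C@H]1CC[C@H](N)CC1)c1ccc(F)cc1` keeps everything of compound 2 except the group on the amide nitrogen: 1-(4-fluorophenyl)ethyl in place of benzyl on an amide-type nitrogen. Among the compounds with values here, because compound 2 gives 7000 nM and no other step is known, the expected step of a 1.4-fold lower number from compound 2 to compound 3 (0.15 log units; within the scatter) is small, within the scatter and with no clear direction. Compound 3 is estimated at 5000 nM, within 2000 nM to 14000 nM.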

Compound 3, half-maximal inhibitory concentration: > 10000 nM
Compound 3: a limit, no number; the forecaster's own chance of this, stated with the estimate: 10%; middle value at least 2.0-fold (0.30 log units) from the limit.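

In this assay compound 3 gives > 10000 nM, which is a limit of the assay and not a number. Putting 1-(4-fluorophenyl)ethyl in place of benzyl on the amide-type nitrogen gives an at least 1.4-fold higher number from compound 2 to compound 3 (0.15 log units; that floor lies within the scatter). This is the first change at this position that can be read, and since the step is only a floor, it shows no lower number and leaves the true size of the gap unknown, with the reading stopped at the assay's limit: the limit of > 10000 nM in this assay, at which 1 of the 3 values shown sits.

The new group differs from benzyl in both its fluorine and its branched carbon with a defined stereocentre, so a single step cannot show which of these matters. Going by these compounds, how a plain 4-fluorobenzyl group, a longer chain such as 3-phenylpropyl, or an amine-bearing chain on this nitrogen would read in this assay remains open.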